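This account rests on a few compounds, and the source may have more. Where it says the series, first, only, none or still open, it means among the compounds named here.

In a functional assay on MIA PaCa-2 cells (Homo sapiens) for inhibition, read by MTT assay (a lower number here means a stronger inhibitor, a higher number a weaker inhibitor), two compounds sharing one core have been measured so far. Compound 1 `O=C(c1cc2cnc(Nc3ccc(N4CCNCC4)cn3)nc2n1C1CCCC1)N1CCCCC1`, with piperidin-1-yl on its carbonyl carbon, gives 39600 nM. Compound 2 `COc1ccccc1NC(=O)c1cc2cnc(Nc3ccc(N4CCNCC4)cn3)nc2n1C1CCCC1`, with (2-methoxyphenyl)amino in that place, gives 1830 nM, the lower of the two numbers and so the stronger inhibitor of the pair. Compound 3 `COc1ccc(NC(=O)c2cc3cnc(Nc4ccc(N5CCNCC5)cn4)nc3n2C2CCCC2)cc1` has the same atoms as compound 2, joined differently: 4-methoxyphenyl in place of 2-methoxyphenyl on an amide-type nitrogen. Going by the values given here, only one measured step bears on this change, a 22-fold lower number from compound 1 to compound 2 (1.34 log units; beyond the scatter), which is large and beyond the scatter. Among the compounds with values here, that step replaced a whole group, though, and no measurement yet compares 2-methoxyphenyl with 4-methoxyphenyl. On these data alone, a step beyond the scatter in this assay is therefore not expected, and its direction remains open. The estimated step is a 1.3-fold higher number from compound 2 to compound 3 (0.10 log units; within the scatter). For compound 3 the expected value is 2300 nM, with an estimated range of 700 nM to 7500 nM.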

Compound 3, half-maximal inhibitory concentration: 2880 nM
Compound 3: middle estimate off by 1.3-fold (0.10 log units), on the low side; the measured number falls inside the stated range.
By their numbers in this assay, from the lowest: compounds 2 and 3 (each within the scatter of the next); then compound 1.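

In this assay, going from 2-methoxyphenyl to 4-methoxyphenyl on the amide-type nitrogen gives a 1.6-fold higher number from compound 2 to compound 3 (0.20 log units; within the scatter) and so leaves the two compounds indistinguishable in this assay. The large drop seen earlier with the first methoxyphenyl amide also appears with the second, as a 14-fold lower number from compound 1 to compound 3 (1.14 log units; beyond the scatter) shows, so it does not depend on which of these two methoxyphenyl groups is present. Nothing available explains why these groups give such numbers.

The compounds shown leave open whether the methoxy group contributes at all, since an unsubstituted phenyl on the same nitrogen would be needed to separate the effect of the ring from that of its methoxy group. They also leave open how a different group on the ring, such as a chlorine, a hydroxyl or a carboxylic acid, would read here.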